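Replacing the Pendant Aryl Group of Compound 2 with Methyl

The source may hold more compounds than are shown below. What is called first, only, known or untested is meant among the compounds shown, and "the series" means these compounds.

Measured compounds:
- Compound 1 `Cc1nc2c3ccccc3ccc2c2nc3c(ccc4ccccc43)c(-c3cccnc3)c12`: 34200 nM
- Compound 2 `Cc1nc2c3ccccc3ccc2c2nc3c(ccc4ccccc43)c(-c3cc(O)nc4ccccc34)c12`: 4630 nM

In a functional assay on HCT-116 cells (Homo sapiens) for cytotoxicity, read by MTT assay, with a stated time of 48 h (on this read-out higher numbers stand for weaker inhibition and lower numbers for stronger inhibition), compound 2 gives 4630 nM, the lowest of the two numbers recorded; compound 1 gives 34200 nM. Among the compounds with values here, the only step known so far is a 7.4-fold lower number from compound 1 to compound 2 (0.87 log units; beyond the scatter). That step shows that swapping pyridin-3-yl for the larger 2-hydroxyquinolin-4-yl on the shared core moved the number in the favourable direction.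

Compound 3 `Cc1nc2c3ccccc3ccc2c2nc3c(ccc4ccccc43)c(C)c12` takes the opposite route: methyl in place of 2-hydroxyquinolin-4-yl on an aromatic carbon. The aromatic group is removed altogether and replaced with the smallest possible substituent. Within the data shown here, no measured step covers this exact change, but the single step in hand suggests that the group at this position matters, and removing it is expected to push the number back up, likely past compound 1. The step from compound 2 to compound 3 is therefore estimated as an 8.6-fold higher number from compound 2 to compound 3 (0.94 log units; beyond the scatter), and compound 3 is expected to give about 40000 nM, within 10000 nM to 120000 nM.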

Compound 3, half-maximal inhibitory concentration: > 80000 nM
Compound 3 ended at the assay's limit; the forecaster's own chance of this, stated with the estimate: 20%; middle value at least 2.0-fold (0.30 log units) from the limit.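

In this assay compound 3 gives > 80000 nM, which is a limit of the assay and not a number. Even so, both new steps are beyond the scatter, an at least 17-fold higher number from compound 2 to compound 3 (1.23 log units; beyond the scatter) and an at least 2.3-fold higher number from compound 1 to compound 3 (0.36 log units; beyond the scatter), so either aromatic group at this carbon gives a lower number than methyl does. Within the data shown here, the earlier compounds compared only two aromatic groups, whereas these three now fall in one order, with the number lowest for 2-hydroxyquinolin-4-yl, higher for pyridin-3-yl and highest for methyl.

Going by these compounds, how far compound 3 lies past the limit remains open, and so does the full size of both steps. Also open, on these data alone, is whether the hydroxy group of compound 2 counts, which a plain quinolin-4-yl would test, and how an amine or a longer alkyl chain would behave at this carbon.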